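The compounds below may be only part of what the source reports. "The series", "measured", "known", "first", "only" and "open" are said of these compounds alone.

Values measured in a functional assay on A549 cells (Homo sapiens) for antiproliferative activity, read by sulforhodamine B assay, with a stated time of 72 h; a lower number here means a stronger inhibitor, a higher number a weaker inhibitor:
- Compound 1 `COc1cc2occ(-c3csc4ccccc34)c(=O)c2cc1OC`: > 10000 nM, a limit of the assay
- Compound 2 `COc1cc2c(=O)c(-c3csc4ccccc34)coc2c(OC)c1OC`: > 10000 nM, a limit of the assay
- Compound 3 `O=C(/C=C/c1csc2ccccc12)c1ccccc1O`: 5300 nM

Of these three results, only compound 3 at 5300 nM is an actual number. Compound 1 and compound 2 both stop at the limit of > 10000 nM in this assay, at which 2 of the 3 values shown sit.

Compound 4 `O=C(/C=C/c1csc2ccccc12)c1cc(F)ccc1O` is built from compound 3 by one small change: fluoro in place of hydrogen on an aromatic carbon. The fluoro group replaces a hydrogen on an aromatic carbon, para to a hydroxy group.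

Among the compounds with values here, only one measured step is available for comparison, and it involves a different group on a different core. That step, a step that the two limits leave unreadable from compound 1 to compound 2, gives no size to carry over. With nothing to favour either direction, the expected step of a 1.2-fold lower number from compound 3 to compound 4 (0.07 log units; within the scatter) is estimated to stay within the usual scatter of this assay.

For compound 4 the expected value is 4500 nM, with an estimated range of 1800 nM to 10000 nM.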

Compound 4, half-maximal inhibitory concentration: 7100 nM
Compound 4: the middle estimate sits 1.6-fold (0.20 log units) below what was measured, within the range that was stated.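

In this assay, within the data shown here, fluoro in place of hydrogen on this aromatic carbon, para to a hydroxy group, gives a 1.3-fold higher number from compound 3 to compound 4 (0.13 log units; within the scatter), the first step here with a readable size. Among these compounds, the only earlier step cannot be read, because both of its compounds stop at a limit of the assay: the limit of > 10000 nM in this assay, at which 2 of the 4 values shown sit. Compound 3 and compound 4 both give actual numbers, and at this position the fluoro group yields a compound that this assay cannot tell apart from the one carrying hydrogen.

The compounds shown leave open whether another group on this carbon, such as an amine or a carboxylic acid, would move the number beyond the scatter. A single fluoro step also says nothing about the other positions on this six-membered aromatic ring.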